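Swapping fluoro for chloro in a two-compound series

A few compounds are considered here, and "the series" means these few. Any claim that something is new, unique, unknown or untested is made for them only; others in the source may bear on it.

In an ADME assay on MT4 cells (Homo sapiens) for cytotoxicity, read by spectrophotometry, with a stated time of 5 days (on this read-out lower numbers stand for higher toxicity in this test and higher numbers for lower toxicity in this test), compound 1 (`CONC(=S)N/N=C1\C(=O)N(CN(C)C)c2ccc(F)cc21`) gives 560000 nM and compound 2 (`CN(C)CN1C(=O)/C(=N\NC(=S)NO)c2cc(F)ccc21`) gives 599000 nM on the same read-out. These two numbers stand level within the scatter, so compound 2 sits alongside compound 1 and cannot be placed ahead of it. The next compound to be measured is compound 3 (`CN(C)CN1C(=O)/C(=N\NC(=S)NO)c2cc(Cl)ccc21`), which differs from compound 2 by chloro in place of fluoro on an aromatic carbon and by nothing else. Going by the values given here, only one measured step exists, a 1.1-fold higher number from compound 1 to compound 2 (0.03 log units; within the scatter) for hydrogen in place of methyl on an oxygen, and it stays within the scatter. Among the compounds with values here, that step involves a different part of the molecule, so it shows only that the number held steady under another change. Within the data shown here, no measurement yet tests the exchange of fluoro for chloro. A shift beyond the scatter is therefore not expected, and the estimated step, a 1.2-fold lower number from compound 2 to compound 3 (0.10 log units; within the scatter) in size, is a cautious allowance. Compound 3 is estimated at 480000 nM with an expected range from 230000 nM to 850000 nM when it is measured.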

Compound 3, half-maximal cytotoxic concentration: 610000 nM
Compound 3: the middle estimate sits 1.3-fold (0.10 log units) below what was measured; low and high end bracket the measured number.
By their numbers in this assay, from the lowest: compounds 1, 2 and 3 (each within the scatter of the next).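

In this assay, going by these compounds alone, the exchange of fluoro for chloro on an aromatic carbon now has a measured step of its own, a 1.0-fold higher number from compound 2 to compound 3 (0.01 log units; within the scatter), and this is the first reading at this position, meta to a fused ring and para to a fused ring. On this read-out, fluoro and chloro at this place cannot be told apart, just as the earlier change on the oxygen, a 1.1-fold higher number from compound 1 to compound 2 (0.03 log units; within the scatter), could not be told apart at its own site, so changes at two separate places have now left all three compounds level. No available evidence bears on why the number holds steady across this exchange.

What the compounds leave open is whether this position tolerates anything beyond these two halogens, for example a hydrogen, a methoxy group, an amine or a carboxylic acid, since neither halogen gives a step beyond the scatter. On these data alone, it also remains open whether chloro and fluoro would stay level on a compound carrying the methyl on the oxygen, as compound 1 does.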